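Ortho-halophenyl pyrimidine sulfamides: chloro to fluoro swap

The source may report more compounds than this note shows. Statements on the series, on what has been measured and on what is new or still open speak of the compounds shown alone.

Measured compounds:
compound 1 `NS(=O)(=O)NCC1CCN(c2cc(-c3ccccc3F)ncn2)CC1`: 80400 nM
compound 2 `NS(=O)(=O)NCCC1CCN(c2cc(-c3ccccc3Cl)ncn2)CC1`: 52900 nM

In a functional assay on HT-29 cells (Homo sapiens) for antiproliferative activity, read by sulforhodamine B assay, with a stated time of 48 h (on this read-out lower numbers stand for stronger inhibition of growth and higher numbers for weaker inhibition of growth), compound 2 gives the lowest of the two numbers, with compound 1 the nearest, a gap within the scatter. Compound 3 `NS(=O)(=O)NCCC1CCN(c2cc(-c3ccccc3F)ncn2)CC1` differs from compound 2 by fluoro in place of chloro on an aromatic carbon. Within the data shown here, no step of this kind is measured here; the two values shown do not separate the halogens beyond the scatter. The expected step from compound 2 to compound 3 in this assay is a 1.3-fold higher number from compound 2 to compound 3 (0.12 log units; within the scatter), nothing beyond the scatter. Compound 3 is estimated at 70000 nM, between 30000 nM and 160000 nM.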

Compound 3, concentration for 50% growth inhibition: 51800 nM
The estimate for compound 3 lay 1.4-fold (0.13 log units) above the measured number; low and high end bracket the measured number.
By their numbers in this assay, from the lowest: compounds 3, 2 and 1 (each within the scatter of the next).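

In this assay, 2-chlorophenyl to 2-fluorophenyl gives a 1.0-fold lower number from compound 2 to compound 3 (0.01 log units; within the scatter) and so does not separate the two halogens on this aromatic carbon, ortho to a large group. The swap of (sulfamoylamino)methyl for sulfamoylamino on the saturated chain gives a 1.6-fold lower number from compound 1 to compound 3 (0.19 log units; within the scatter) and thus adds a direct reading that this chain change also stays within the scatter. Nothing available bears on the reasons for either result. Open, going by these compounds, is whether a methoxy or an amine at this aromatic position moves the number beyond the scatter. Also open, on these data alone, is whether a longer chain does so.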